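A few compounds are considered here, and "the series" means these few. Any claim that something is new, unique, unknown or untested is made for them only; others in the source may bear on it.

Compound 1, `O=C(COc1ccc2ccccc2c1)N1CCN(C(c2ccc(Br)cc2)c2ccc(Br)cc2)CC1`, was tested in a functional assay on PC-12 cells (Rattus norvegicus) for cytotoxicity, read by MTT assay, with a stated time of 24 h, tested at 10 uM (on this read-out higher numbers stand for a stronger effect at the one concentration tested and lower numbers for a weaker effect), where compound 1 gives 30.2%. Among the three measured compounds that is the second highest number. Its nearest neighbour is compound 2, `COc1ccc(C(c2ccc(OC)cc2)N2CCN(C(=O)COc3ccccc3C)CC2)cc1`, which gives 21.2%, a number within the usual scatter of the number for compound 1. Furthest away is compound 3, `COc1ccc(OCC(=O)N2CCN(C(c3ccc(F)cc3)c3ccc(F)cc3)CC2)cc1`, which gives 80.5%, a number beyond the scatter and higher than that of compound 1. Compound 4, `COc1ccccc1OCC(=O)N1CCN(C(c2ccc(Br)cc2)c2ccc(Br)cc2)CC1`, differs from compound 1 in one place: 2-methoxyphenyl in place of naphthalen-2-yl on an oxygen on a saturated carbon. Going by the values given here, no measured pair shows this change on its own, so its effect is not known from these data. Compound 4 is expected to move only a little, with a step of a number 4.8 percentage points higher from compound 1 to compound 4 (within the scatter) that may well stay within the scatter. Compound 4 is therefore estimated at 35%, in a range from 15% to 65%.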

Compound 4, a percentage reported as activity, at one concentration (the size of the read-out at that concentration, not a potency): 6.67%
Beside the measured number, compound 4's estimate is 28.3 percentage points above it; the whole stated range lies above it.
By their numbers in this assay, from the lowest: compound 4; then compounds 2 and 1 (each within the scatter of the next); then compound 3.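

Going by these compounds alone, the first comparison that changes only one place shows that this position matters: in this assay, 2-methoxyphenyl in place of naphthalen-2-yl on the oxygen gives a number 23.5 percentage points lower from compound 1 to compound 4 (beyond the scatter). The read-out therefore responds to this group while the rest of compound 1 stays fixed. Nothing measured here explains the drop.

The compounds shown leave open whether the step follows from losing the second aromatic ring or from gaining the methoxy group. A plain phenyl in the same place would help separate those two changes.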